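The source may hold more compounds than are shown below. What is called first, only, known or untested is meant among the compounds shown, and "the series" means these compounds.

Compound 1 `CNc1nc(NCc2ccc(C(=O)NC3CCN(Cc4ccc(F)cc4)CC3)cc2)c2cc(C)ccc2n1` — in a functional assay on SW480 cells (Homo sapiens) for inhibition, read by luminescence and resazurin assay, with a stated time of 3 days (on this read-out higher numbers stand for weaker inhibition and lower numbers for stronger inhibition), compound 1 gives 1300 nM.
Compound 2 `CCNc1nc(NCc2ccc(NC(=O)c3ccc(F)cc3)cc2)c2ccccc2n1` — in this assay compound 2 gives 2300 nM.
Compound 3 `CCNc1nc(NCc2ccc(C(=O)Nc3ccc(F)cc3)cc2)c2ccccc2n1` — in this assay compound 3 gives 2500 nM.

Compound 3 holds the highest of the three numbers, yet its gaps to compound 2 and to compound 1 both fall within the scatter, so no order among them can be claimed. Within the data shown here, the only single-point step measured, a 1.1-fold higher number from compound 2 to compound 3 (0.04 log units; within the scatter), lies within the scatter as well.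

Compound 4 `CCCCNc1nc(NCc2ccc(C(=O)Nc3ccc(F)cc3)cc2)c2ccccc2n1` differs from compound 3 by ethyl in place of hydrogen on a saturated chain carbon, two bonds along the chain from a nitrogen on an aromatic ring. Among the measured compounds shown here, no measured step touches this chain; compound 1 carries a shorter chain on that ring nitrogen but differs from compound 3 in several other places, so its value bears only loosely. The author therefore expects no step beyond the scatter, no change at the digits printed from compound 3 to compound 4 (within the scatter). Compound 4 is estimated at 2500 nM, within a range of 1000 nM to 6000 nM.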

Compound 4, half-maximal inhibitory concentration: 1000 nM
Compound 4: the middle estimate sits 2.5-fold (0.40 log units) above what was measured, within the range that was stated.
By their numbers in this assay, from the lowest: compounds 4, 1, 2 and 3 (each within the scatter of the next, the first and the last beyond it).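

In this assay the change from ethylamino to butylamino gives a 2.5-fold lower number from compound 3 to compound 4 (0.40 log units; beyond the scatter), so this chain is a place where added carbon moves the number beyond the scatter, though modestly. The one earlier single-place step, at the linking carbamoyl, had shown no such movement. Nothing at hand explains the step.

As far as these compounds go, whether a hexyl chain, an isobutyl group or a cyclopropylmethyl group in place of butyl would lower the number further stays open. A single step does not establish a trend with chain length.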